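A Fluoro-to-Methyl Swap on a Shared Core

The source may hold more compounds than are shown below. What is called first, only, known or untested is meant among the compounds shown, and "the series" means these compounds.

Compound 2 `O=[N+]([O-])c1ccc(Cn2cc(CO/N=C/c3c(-c4ccc(F)cc4)nc4ccc(Br)cn34)nn2)cc1` was tested in a functional assay on the whole organism (strain NMRI) with Mus musculus as the target, with a stated time of 4 h; on this read-out lower numbers stand for an effect already at smaller amounts and higher numbers for an effect only at larger amounts of compound. There compound 2 gives 100 mg/kg, and compound 1 `C#CCO/N=C/c1c(-c2ccc(F)cc2)nc2c(C)cccn12` gives 100 mg/kg, so the two stand level within the usual scatter of this assay. Compound 3 `Cc1ccc(-c2nc3ccc(Br)cn3c2/C=N/OCc2cn(Cc3ccc([N+](=O)[O-])cc3)nn2)cc1` awaits measurement. It differs from compound 2 by methyl in place of fluoro on an aromatic carbon. Within the data shown here, no step between measured compounds covers this change, so the expectation rests on compound 2 alone, and the step of no change at the digits printed from compound 2 to compound 3 (within the scatter) is expected to remain within the scatter. Compound 3 is accordingly estimated at 100 mg/kg, with a range from 50 mg/kg to 200 mg/kg.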

Compound 3, minimum effective dose: 20 mg/kg
Estimate against measurement, compound 3: 5.0-fold (0.70 log units) above; measured number below the stated range.
By their numbers in this assay, from the lowest: compound 3; then compounds 1 and 2 (each within the scatter of the next).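

Going from the 4-fluorophenyl to the 4-methylphenyl group gives in this assay a 5.0-fold lower number from compound 2 to compound 3 (0.70 log units; beyond the scatter), so the read-out responds to what this aromatic carbon carries. The earlier compounds shown here could not show this, as compound 1 and compound 2 both carry the 4-fluorophenyl group. Nothing available explains why the methyl group gives the lower number.

As far as these compounds go, it remains open whether an ethyl group, a methoxy group or a chlorine atom at this place would go further in the same direction. From the compounds shown here alone, whether the same swap has a similar effect on the core of compound 1 also remains open.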